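The compounds below may be only part of what the source reports. "The series", "measured", "known", "first", "only" and "open" are said of these compounds alone.

Measured so far:
compound 1, `CNC(=O)[C@@]12C[C@@H]1[C@@H](n1cnc3c(NC)nc(C#Cc4ccccc4OC)nc31)[C@H](O)[C@@H]2O`: 12%
compound 2, `CNC(=O)[C@@]12C[C@@H]1[C@@H](n1cnc3c(NC)nc(C#Cc4cccnn4)nc31)[C@H](O)[C@@H]2O`: 11%

In an assay on CHO cells for displacement of a labelled ligand from adenosine receptor A1 (Homo sapiens), read by scintillation counting, with a stated time of 60 min, tested at 10 uM (on this read-out lower numbers stand for less inhibition and higher numbers for more inhibition at the one concentration tested (going by the name of the read-out)), compound 1 gives 12%, and compound 2 gives 11%. The two numbers lie within the scatter of each other, so compound 1 cannot be called higher or lower than compound 2 on this read-out. Among the measured compounds shown here, the one recorded step between them, a number 1 percentage points lower from compound 1 to compound 2 (within the scatter), replaced the group on a triple-bonded carbon and moved the number by less than the scatter.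

Compound 3 has the structure `CNC(=O)[C@@]12C[C@@H]1[C@@H](n1cnc3c(NC)nc(C#CC4CC4)nc31)[C@H](O)[C@@H]2O`. It differs from compound 1 at the same place: cyclopropyl in place of 2-methoxyphenyl on a triple-bonded carbon. For the measured compounds named here, the only measured step that bears on this change is a number 1 percentage points lower from compound 1 to compound 2 (within the scatter), where a different group on a triple-bonded carbon left the read-out essentially where it was. On that basis the step of a number 2 percentage points lower from compound 1 to compound 3 (within the scatter) is expected to stay within the scatter. Compound 3 is therefore estimated at 10%, with a range from 2% to 25%.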

Compound 3, a percentage reported as inhibition, at one concentration (the size of the read-out at that concentration, not a potency): 38%
Beside the measured number, compound 3's estimate is 28 percentage points below it; the whole stated range lies below it.
By their numbers in this assay, from the lowest: compounds 2 and 1 (each within the scatter of the next); then compound 3.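

In this assay, putting cyclopropyl on the triple-bonded carbon in place of 2-methoxyphenyl gives a number 26 percentage points higher from compound 1 to compound 3 (beyond the scatter), and putting it there in place of pyridazin-3-yl gives a number 27 percentage points higher from compound 2 to compound 3 (beyond the scatter). The position therefore does respond to the group it carries, something the first two compounds could not show, since 2-methoxyphenyl and pyridazin-3-yl left the numbers within the scatter of each other. No accompanying measurement says why the number rose.

Among the compounds shown here, with only three groups compared, it stays open whether the three-membered ring itself matters or simply the smaller count of heavy atoms, since neither an open chain such as propyl nor a larger ring such as cyclopentyl appears here. These numbers also come from a single concentration, so they show the size of the inhibition at that concentration and not a potency.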